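This account rests on a few compounds, and the source may have more. Where it says the series, first, only, none or still open, it means among the compounds named here.

The series is built on a shared core that carries a nitrophenyl arm on one side and a methoxy-substituted aryl arm on the other. Compound 1 `COc1cc(/C=C2\Cc3ccccc3/C(=C\c3ccc([N+](=O)[O-])cc3)C2=O)cc(OC)c1OC` bears a trimethoxy pattern on a fused core and gives 3000 nM in a functional assay on HSG cells (Homo sapiens) for cytotoxicity; a higher number here means that more compound is tolerated, a lower number that less compound is tolerated. Compound 2 `COc1ccc(/C=C2\CCC/C(=C\c3ccc([N+](=O)[O-])cc3)C2=O)cc1OC` moves to a non-fused core with two methoxy groups; in this assay compound 2 gives 13000 nM. Compound 3 `COc1cc(/C=C2\CCC/C(=C\c3ccc([N+](=O)[O-])cc3)C2=O)cc(OC)c1OC` keeps that core with three methoxy groups, and in this assay compound 3 gives 8300 nM.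

For the measured compounds named here, compound 2 therefore holds the highest of the three numbers, with compound 3 nearest and compound 1 furthest, and the only single-point step among them, a 1.6-fold lower number from compound 2 to compound 3 (0.19 log units; within the scatter), stays within the scatter.

Compound 4 `COc1ccc(/C=C2\CCC/C(=C\c3ccc([N+](=O)[O-])cc3)C2=O)cc1` is the next point on the same core. Relative to compound 2 it has hydrogen in place of methoxy on an aromatic carbon. Going by the values given here, the one measured step that touches the same aryl ring, a 1.6-fold lower number from compound 2 to compound 3 (0.19 log units; within the scatter), is small, so removing a methoxy is expected to leave the number roughly where compound 2 sits, with no step beyond the scatter in this assay in either direction. On that basis compound 4 is expected to give 12000 nM, with a plausible range from 5000 nM to 30000 nM, which would mean a 1.1-fold lower number from compound 2 to compound 4 (0.03 log units; within the scatter).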

Compound 4, half-maximal cytotoxic concentration: > 400000 nM
Compound 4: no number, only a limit (the forecaster's own chance of this, stated with the estimate: 10%); middle value at least 33-fold (1.52 log units) away from the limit.
By their numbers in this assay, from the lowest: compound 1; then compounds 3 and 2 (each within the scatter of the next). At a limit, above all of these: compound 4.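

In this assay, taking the methoxy off this aromatic carbon, which sits ortho to a methoxy group and meta to a large group, gives an at least 30-fold higher number from compound 2 to compound 4 (1.48 log units; beyond the scatter), so far more compound is tolerated once that group is gone. The earlier compounds had shown only that the same aryl ring accepts one more methoxy with no change beyond the scatter, a 1.6-fold lower number from compound 2 to compound 3 (0.19 log units; within the scatter), and the ring therefore looked insensitive; the new step shows that losing this methoxy counts for far more than gaining the other one. The reading for compound 4 is a limit and not a number: the limit of > 400000 nM in this assay, at which 1 of the 4 values shown sits.

The compounds shown leave open whether the methoxy itself is what matters on this carbon, or whether a hydroxyl, an ethoxy, a fluorine or an amine in its place would stay close to compound 2 or move towards compound 4. They also leave open whether the same loss of a methoxy would have a step of this kind on the core of compound 1.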